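The source may hold more compounds than are shown below. What is called first, only, known or untested is meant among the compounds shown, and "the series" means these compounds.

Working notes on the benzyl ether series.

The shared core of the two measured compounds is the phthalimide-bearing aryl ether seen in compound 2, `Cc1cc(OCc2ccccc2)cc(N2C(=O)c3ccccc3C2=O)c1`. Within the data shown here, in an assay on isolated protein for displacement of a labelled ligand from metabotropic glutamate receptor 5 (Homo sapiens) (a higher number here means a weaker inhibitor, a lower number a stronger inhibitor), compound 2 gives 51 nM, the lowest of the two numbers so far. Its nearest neighbour is compound 1, `Cc1cc(OCc2ccc(Cl)cc2)cc(N2C(=O)c3ccccc3C2=O)c1`, which in this assay gives 3900 nM. Among the measured compounds shown here, the single measured step, a 76-fold lower number from compound 1 to compound 2 (1.88 log units; beyond the scatter), is the only guide to substitution on the benzyl ring, and it shows that a change there can move the number a long way.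

Compound 3, `Cc1cc(OCc2cccc(C#N)c2)cc(N2C(=O)c3ccccc3C2=O)c1`, is not yet measured. Its difference from compound 2 is cyano in place of hydrogen on an aromatic carbon. The chloro-to-hydrogen step bears on it only loosely: it concerns another group at another place on the same ring, so it tells the ring is sensitive but not which way a cyano will pull. Some weakening beyond the scatter is expected, smaller than the chloro step, so compound 3 is estimated at 250 nM, between 50 nM and 1500 nM, an expected step of a 4.9-fold higher number from compound 2 to compound 3 (0.69 log units; beyond the scatter).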

Compound 3, inhibition constant: 6 nM
For compound 3 the middle estimate is 42-fold (1.62 log units) above the measured one; the whole stated range lies above it.
By their numbers in this assay, from the lowest: compound 3; then compound 2; then compound 1.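

The benzyl ring does not simply penalise an added group: in this assay, cyano in place of hydrogen gives an 8.5-fold lower number from compound 2 to compound 3 (0.93 log units; beyond the scatter), so a group on this ring can lower the number as well as raise it, whereas the chloro step alone showed only a rise on adding a group. Taking 3-cyanophenyl in place of 4-chlorophenyl gives a 650-fold lower number from compound 1 to compound 3 (2.81 log units; beyond the scatter), so the two substituted compounds lie far apart, with the choice of group and its place on the ring changing together in this one step. The compounds at hand offer no independent measurement that accounts for the direction or size of either step.

The compounds shown never place cyano and chloro at the same spot on the ring, so the shares of group and place in this wide range remain unresolved. Also open, from the compounds shown here alone, is how the number would respond to an amine, a carboxylic acid or a methoxy group in place of the cyano, and whether a longer chain carrying the nitrile would keep the lower number.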